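The source may report more compounds than this note shows. Statements on the series, on what has been measured and on what is new or still open speak of the compounds shown alone.

Compound 1, `COc1cccc(-c2ccc3c(NC(=O)c4ccc(N5CCN(C)CC5)c(F)c4)n[nH]c3c2)c1F`, gives > 1000 nM in a functional assay on KG-1 cells (Homo sapiens) for antiproliferative activity, read by CCK-8 assay, with a stated time of 72 h; on this read-out higher numbers stand for weaker inhibition and lower numbers for stronger inhibition; this is a limit of the assay, not a number. Compound 2, `COc1ccc(F)c(-c2ccc3c(NC(=O)c4ccc(N(C)CCN(C)C)cc4)n[nH]c3c2)c1F`, gives 333 nM.

Among the compounds with values here, compound 2 thus holds the only actual number measured here; the other result recorded is the limit of > 1000 nM in this assay, at which 1 of the 2 values shown sits, so no step between measured compounds can be drawn, and the two values together show only that compound 2 was inhibitory within the measured range while compound 1 was not.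

Compound 3, `COc1ccc(F)c(-c2ccc3c(NC(=O)c4ccc(N5CCCN(C)CC5)cc4)n[nH]c3c2)c1F`, differs from compound 2 in one place: 4-methyl-1,4-diazepan-1-yl in place of (2-(dimethylamino)ethyl)(methyl)amino on an aromatic carbon. Within the data shown here, with no measured step to lean on, the change is expected to move the result by no more than the usual scatter, in no settled direction. Compound 3 is therefore estimated at about 500 nM, with a range from 150 nM to 2000 nM. That estimate amounts to an expected step of a 1.5-fold higher number from compound 2 to compound 3 (0.18 log units; within the scatter) lying within the scatter.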

Compound 3, half-maximal inhibitory concentration: 51.5 nM
Estimate against measurement, compound 3: 9.7-fold (0.99 log units) above; the measured number lies below the stated range.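

In this assay, replacing the open chain with the ring on this aromatic carbon, para to a large group, gives a 6.5-fold lower number from compound 2 to compound 3 (0.81 log units; beyond the scatter), so the result at this position depends on which group stands there. The two groups have the same counts of hydrogen-bond donors and acceptors and neither carries a net charge, so those counts do not separate them. Nothing measured here explains why the 4-methyl-1,4-diazepan-1-yl group gives the lower number.

From the compounds shown here alone, whether a morpholine ring or a longer chain ending in a dimethylamino group would give a similar number at this position remains open. Compound 1 differs from the other two compounds in more than one place and its result is a limit, so it adds nothing to this comparison.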